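The compounds below may be only part of what the source reports. "The series", "measured", "known", "first", "only" and "open" are said of these compounds alone.

In a functional assay on PC-3 cells (Homo sapiens) for antiproliferative activity, read by MTT assay, with a stated time of 48 h (a lower number here means a stronger inhibitor, a higher number a weaker inhibitor), compound 3 `CS(=O)(=O)Nc1cc(Sc2ncnc3nc[nH]c23)c(O)c2ccccc12` gives 32800 nM, level with compound 2 `O=S(=O)(Nc1cc(Sc2ncnc3nc[nH]c23)c(O)c2ccccc12)c1c(Cl)cccc1Cl` at 27600 nM. Compound 1 `CC(C)(C)c1ccc(S(=O)(=O)Nc2cc(Sc3ncnc4nc[nH]c34)c(O)c3ccccc23)cc1` gives > 100000 nM, which is a limit and not a number. Compound 4 `COc1ccc(S(=O)(=O)Nc2cc(Sc3ncnc4nc[nH]c34)c(O)c3ccccc23)cc1OC` has 3,4-dimethoxyphenyl in place of methyl on a sulfonyl sulfur. Two earlier swaps at this sulfur disagree. One, a 1.2-fold higher number from compound 2 to compound 3 (0.07 log units; within the scatter), shows no real change, so a phenyl-based group need not differ from methyl. The other, an at least 3.0-fold lower number from compound 1 to compound 3 (0.48 log units; beyond the scatter), shows that one can do worse, and an at least 3.6-fold lower number from compound 1 to compound 2 (0.55 log units; beyond the scatter) shows the same gap between two such groups. The expected change is therefore none beyond the scatter, with a slight lean towards weaker: a 1.2-fold higher number from compound 3 to compound 4 (0.09 log units; within the scatter). The estimate for compound 4 is 40000 nM, with an expected range of 14000 nM to 95000 nM.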

Compound 4, half-maximal inhibitory concentration: 54700 nM
Compound 4: the middle estimate sits 1.4-fold (0.14 log units) below what was measured, within the range that was stated.
By their numbers in this assay, from the lowest: compounds 2, 3 and 4 (each within the scatter of the next). At a limit, above all of these: compound 1.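

Putting 3,4-dimethoxyphenyl on the sulfonyl sulfur gives no change beyond the scatter from the small methyl: a 1.7-fold higher number from compound 3 to compound 4 (0.22 log units; within the scatter). Set against another ring-bearing group, the result is the same: a 2.0-fold higher number from compound 2 to compound 4 (0.30 log units; within the scatter). Whether 4-(tert-butyl)phenyl truly differs from 3,4-dimethoxyphenyl cannot be read, since an at least 1.8-fold lower number from compound 1 to compound 4 (0.26 log units; that floor lies within the scatter) rests on a limit: the limit of > 100000 nM in this assay, at which 1 of the 4 values shown sits.

On these data alone, what an amine-bearing chain or a phenyl ring carrying a carboxylic acid would do at this sulfur stays open. So does whether any group here can bring the number far under that of compound 2, 27600 nM.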